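Aryl sulfanyl extension of the benzoylguanidine series

The source may report more compounds than this note shows. Statements on the series, on what has been measured and on what is new or still open speak of the compounds shown alone.

Measured compounds:
- compound 1 `CCCCCc1cc(C)c(C(=O)N=C(N)N)cc1S(C)(=O)=O`, 27 nM
- compound 2 `Cc1cc(C2CCC2)c(S(C)(=O)=O)cc1C(=O)N=C(N)N`, 8.2 nM
- compound 3 `CSc1cc(C)c(C(=O)N=C(N)N)cc1S(C)(=O)=O`, 6 nM

In a functional assay for inhibition of sodium/hydrogen exchanger (Oryctolagus cuniculus) (a higher number here means a weaker inhibitor, a lower number a stronger inhibitor), compound 3 gives the lowest number of the three, but compound 2 lies within the scatter of it, so the two cannot be ordered; only compound 1 sits clearly apart, with a 4.5-fold lower number from compound 1 to compound 3 (0.65 log units; beyond the scatter) and a 3.3-fold lower number from compound 1 to compound 2 (0.52 log units; beyond the scatter).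

Compound 4 `Cc1cc(Sc2cccc(Cl)c2)c(S(C)(=O)=O)cc1C(=O)N=C(N)N` has not yet been measured. Against compound 3 the change is 3-chlorophenyl in place of methyl on a sulfur. For the measured compounds named here, none of the measured steps touches this sulfur: the two steps beyond the scatter both replace pentyl on the aromatic carbon with a smaller group, and the step from cyclobutyl to methylsulfanyl, a 1.4-fold lower number from compound 2 to compound 3 (0.14 log units; within the scatter), stays within the scatter. The only pointer is that the largest of the three substituents, pentyl in compound 1, carries the highest number, and compound 4 again grows the group at that carbon, now further out from the ring.

Going by the values given here, the step of a 2.5-fold higher number from compound 3 to compound 4 (0.40 log units; beyond the scatter) is therefore expected to be a modest rise in the number, with wide uncertainty since no measured pair tests substitution on the sulfur itself. Compound 4 is estimated at 15 nM, within 4 nM to 60 nM.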

Compound 4, half-maximal inhibitory concentration: 37 nM
Beside the measured number, compound 4's estimate is 2.5-fold (0.39 log units) below it; the range from low to high includes it.
By their numbers in this assay, from the lowest: compounds 3 and 2 (each within the scatter of the next); then compounds 1 and 4 (each within the scatter of the next).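

For the compounds shown here, the first measured change on this sulfur gives a 6.2-fold higher number from compound 3 to compound 4 (0.79 log units; beyond the scatter) in this assay, so, unlike the earlier steps at the aromatic carbon, it shows that replacing methyl with 3-chlorophenyl on the sulfur weakens inhibition beyond the scatter. At the aromatic carbon, (3-chlorophenyl)sulfanyl also separates clearly from cyclobutyl (a 4.5-fold higher number from compound 2 to compound 4 (0.65 log units; beyond the scatter)), whereas its comparison with pentyl (a 1.4-fold higher number from compound 1 to compound 4 (0.14 log units; within the scatter)) stays within the scatter, so compound 1 and compound 4 cannot be ordered and the four compounds form two unordered pairs, compound 2 with compound 3 and compound 1 with compound 4. No supporting measurement is available to explain the loss at the sulfur.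

The compounds shown do not separate the contribution of the aromatic ring from that of its chlorine, nor show whether moving the chlorine around the ring changes the number, and a plain phenyl or a benzyl on the sulfur would address the first question. Also open, as far as these compounds go, is how an ethyl, a longer alkyl chain or a chain ending in an amine or a carboxylic acid on the sulfur would compare with methyl and 3-chlorophenyl.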